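Swapping the amide substituent: from an aryl amide to a dinitrile

The source may report more compounds than this note shows. Statements on the series, on what has been measured and on what is new or still open speak of the compounds shown alone.

Measured compounds:
compound 1 `CCN(CC)CCNC(=O)c1ccc(C(CC)(CC)c2ccc(OCC(=O)C(C)(C)C)c(C)c2)n1CC`: 91 nM
compound 2 `CCn1c(C(=O)N(C)c2ccccc2)ccc1C(CC)(CC)c1ccc(OCC(=O)C(C)(C)C)c(C)c1`: 18500 nM

Among the compounds with values here, in an assay on HL-60 cells for agonist activity at vitamin D3 receptor (Homo sapiens), read by microscopy, with a stated time of 96 h (a higher number here means that more compound is needed for the effect, a lower number that less compound is needed), compound 2 gives 18500 nM, the higher of the two numbers measured so far; compound 1 gives 91 nM. Within the data shown here, the one measured step between them, a 200-fold higher number from compound 1 to compound 2 (2.31 log units; beyond the scatter), shows how strongly the group on the carbonyl carbon matters.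

Compound 3 `CCn1c(C(=O)N(CCC#N)CCC#N)ccc1C(CC)(CC)c1ccc(OCC(=O)C(C)(C)C)c(C)c1`, not yet measured, carries a different group at that same place: a group of 9 heavy atoms (6 carbon, 3 nitrogen; no ring) in place of a group of 8 heavy atoms (7 carbon, 1 nitrogen; one six-membered aromatic ring of carbon only), on a carbonyl carbon. The change from compound 2 to compound 3 has no measured counterpart; the only step shown concerns a different pair of groups at the carbonyl carbon, so it bears on this step only by showing that large movements are possible here. Since the change removes the group associated with the high number of compound 2, a lower number is expected for compound 3, though its size is uncertain.

The estimate for compound 3 is 3000 nM, with a range of 400 nM to 20000 nM, meaning an expected step of a 6.2-fold lower number from compound 2 to compound 3 (0.79 log units; beyond the scatter).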

Compound 3, half-maximal effective concentration: 870 nM
Compound 3: middle estimate off by 3.4-fold (0.54 log units), on the high side; the range from low to high includes it.
By their numbers in this assay, from the lowest: compound 1; then compound 3; then compound 2.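

Replacing methyl(phenyl)amino on the carbonyl carbon with a ringless group bearing nitriles gives a 21-fold lower number from compound 2 to compound 3 (1.33 log units; beyond the scatter) in this assay, so the high number of compound 2 does not apply to every tertiary amide in this series. The step of a 9.6-fold higher number from compound 1 to compound 3 (0.98 log units; beyond the scatter) shows that this ringless group still does not match (2-(diethylamino)ethyl)amino, which gives the lowest number of the three groups compared at this place. Nothing measured here explains why these groups differ.

The compounds shown do not separate the contribution of the amide hydrogen in compound 1 from that of its diethylamino end. From the compounds shown here alone, it also remains open where a chain ending in a carboxylic acid, or a longer chain ending in a diethylamino group, would fall on this scale.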